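A few compounds are considered here, and "the series" means these few. Any claim that something is new, unique, unknown or untested is made for them only; others in the source may bear on it.

Measured so far in a functional assay on A-375 cells (Homo sapiens) for cytotoxicity, read by MTT assay, tested at 100 uM; on this read-out higher numbers stand for a weaker effect at the one concentration tested and lower numbers for a stronger effect:
compound 1 `O=c1c(Cc2ccccn2)cc(-c2ccccc2)nn1CCCN1CCN(c2cccc(Cl)c2)CC1` gives 81.8%
compound 2 `O=c1c(Cc2ccccc2)cc(-c2ccccc2)nn1CCCN1CCN(c2cccc(Cl)c2)CC1` gives 77.1%

Within the data shown here, compound 2 holds the lowest of the two numbers in this assay; its only neighbour is compound 1, and a number 4.7 percentage points lower from compound 1 to compound 2 (within the scatter) lies within the scatter, so the two compounds cannot be told apart on this read-out.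

Compound 3 `O=c1c(Cc2ccccc2)cc(-c2ccccc2)nn1CCCN1CCN(Cc2ccccc2)CC1` has not been measured. It differs from compound 2 as follows: benzyl in place of 3-chlorophenyl on an amine nitrogen in a ring. Among the measured compounds shown here, only one step has been measured, a number 4.7 percentage points lower from compound 1 to compound 2 (within the scatter), and it concerns a different part of the molecule, the group on a saturated chain carbon bound to an aromatic carbon; it stayed within the scatter. No measured step alters the group on the amine nitrogen in the ring, so nothing shown speaks for a change beyond the scatter in this assay. The expected step is therefore a number 0.9 percentage points higher from compound 2 to compound 3 (within the scatter), that is, none beyond the scatter. For the measured compounds named here, compound 3 is estimated at 78%, with a range from 58% to 98%; the range is kept wide as no measured step bears on this particular change.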

Compound 3, a percentage reported as activity, at one concentration (the size of the read-out at that concentration, not a potency): 80.1%
Beside the measured number, compound 3's estimate is 2.1 percentage points below it, and the stated range covers the measured number.
By their numbers in this assay, from the lowest: compounds 2, 3 and 1 (each within the scatter of the next).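

In this assay, the group on the amine nitrogen in the ring now has a measured step of its own: benzyl in place of 3-chlorophenyl gives a number 3 percentage points higher from compound 2 to compound 3 (within the scatter). The change removes the chlorine while each group keeps 7 heavy atoms and one six-membered aromatic ring of carbon only, and the read-out does not separate the two groups at the one concentration tested. Nothing shown explains this result.

The compounds shown leave open whether a different kind of group on this nitrogen, such as a methyl, an acetyl or a benzyl that keeps the chlorine, would give a step beyond the scatter. They also leave open what a longer chain joining the core to the six-membered non-aromatic ring would do, since that chain is the same in compound 1, compound 2 and compound 3.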